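The source may report more compounds than this note shows. Statements on the series, on what has been measured and on what is new or still open speak of the compounds shown alone.

Measured so far:
compound 1, `O=c1c(Br)cc2ccccc2n1Cc1nc2ccccc2n1CCCCF`, gives 26200 nM in an ADME assay on HEp-2 cells (Homo sapiens) for cytotoxicity; a higher number here means that more compound is tolerated, a lower number that less compound is tolerated.
compound 2, `CC(C)CCn1c(Cn2c(=O)oc3ccccc32)nc2ccccc21`, gives 30700 nM in this assay.

Compound 1 and compound 2 share a similar frame but differ in several places at once, so no single change links them. Their two numbers lie within the scatter of each other, and neither compound can be called better tolerated than the other; compound 1 simply sits at one end of a very narrow pair.

The next compound, compound 3, `O=c1ccc2ccccc2n1Cc1nc2ccccc2n1CCCCF`, is a close relative of compound 1. It differs in one place only: hydrogen in place of bromo on an aromatic carbon. Nothing else in the molecule moves.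

The only two measured points sit close together: compound 1 gives 26200 nM and compound 2 gives 30700 nM. Among the measured compounds shown here, there is no measured step to lean on. Removing a single bromine atom is a modest change, and the expectation is that the step of a 1.2-fold higher number from compound 1 to compound 3 (0.09 log units; within the scatter) stays within the scatter, if anything drifting toward slightly more compound being tolerated. Compound 3 is therefore estimated at 32000 nM, with a likely range from 15000 nM to 65000 nM.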

Compound 3, half-maximal cytotoxic concentration: 103000 nM
Compound 3: middle estimate off by 3.2-fold (0.51 log units), on the low side, and the stated range ends below it.
By their numbers in this assay, from the lowest: compounds 1 and 2 (each within the scatter of the next); then compound 3.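

Among the compounds shown here, replacing bromo with hydrogen on an aromatic carbon, two atoms from the ring nitrogen, gives the first step in this assay that can be read from one single change, with a 3.9-fold higher number from compound 1 to compound 3 (0.59 log units; beyond the scatter) as its size. This shows that the position matters in this measurement: only one heavy atom leaves, no ring or net charge is involved, and the hydrogen-bond donor and acceptor counts stay at zero for the departing group, yet the step lies beyond the scatter. Of this pair, the compound with hydrogen is the one tolerated at the higher concentration, but no measurement here bears on what lies behind the step.

As far as these compounds go, with only bromo and hydrogen compared at this position, it remains open whether a chlorine atom, a methyl group or an amine placed there would give a number close to that of the bromo compound, close to that of the hydrogen compound, or somewhere in between. From the compounds shown here alone, it also remains open whether the same swap would give a step of similar size on a compound with a longer chain in place of the fluorine-bearing one.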